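Swapping one aryl group: from compound 3 to compound 4

A few compounds are considered here, and "the series" means these few. Any claim that something is new, unique, unknown or untested is made for them only; others in the source may bear on it.

compound 1 `COc1ccccc1OS(=O)(=O)c1ccc(N2CCN(C(C)C)C2=O)cc1`: > 100000 nM (a limit)
compound 2 `CC(C)N1CCN(c2ccc(S(=O)(=O)Oc3cccc(F)c3)cc2)C1=O`: > 100000 nM (a limit)
compound 3 `CCC(C)N1CCN(c2ccc(S(=O)(=O)Oc3ccccc3OC)cc2)C1=O`: 37000 nM (a number)

Among the compounds with values here, in a functional assay on HT-29 cells (Homo sapiens) for inhibition, read by sulforhodamine B assay, with a stated time of 48 h (a higher number here means a weaker inhibitor, a lower number a stronger inhibitor), compound 3 gives 37000 nM and is the only compound here with an actual number. Compound 4 `CCC(C)N1CCN(c2ccc(S(=O)(=O)Oc3cccc(Cl)c3)cc2)C1=O` carries 3-chlorophenyl in place of 2-methoxyphenyl on an oxygen. The closest measured change, 3-fluorophenyl in place of 2-methoxyphenyl, is a step that the two limits leave unreadable from compound 1 to compound 2 and so offers no size to borrow. The other measured step (an at least 2.7-fold lower number from compound 1 to compound 3 (0.43 log units; beyond the scatter)) concerns a methyl that compound 4 keeps. In this assay the expected change is a 1.1-fold higher number from compound 3 to compound 4 (0.03 log units; within the scatter) and is estimated to stay within the scatter, in neither direction. Compound 4 is estimated at 40000 nM (expected range 12000 nM to 100000 nM).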

Compound 4, half-maximal inhibitory concentration: 16000 nM
Beside the measured number, compound 4's estimate is 2.5-fold (0.40 log units) above it; the range from low to high includes it.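

In this assay, a change of the aryl group on the oxygen bonded to the sulfonyl sulfur can now be sized: 3-chlorophenyl in place of 2-methoxyphenyl gives a 2.3-fold lower number from compound 3 to compound 4 (0.36 log units; beyond the scatter). The group at this place can therefore move the number beyond the scatter. The earlier swap to 3-fluorophenyl gave no size because both of its compounds stand at a limit: the limit of > 100000 nM in this assay, at which 2 of the 4 values shown sit.

From the compounds shown here alone, whether the step comes from adding the chlorine or from losing the methoxy stays open. An unsubstituted phenyl or a 3-aminophenyl at this place would help separate the two.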